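A few compounds are considered here, and "the series" means these few. Any claim that something is new, unique, unknown or untested is made for them only; others in the source may bear on it.

Measured compounds:
- compound 1, `Brc1ccc2[nH]c(-c3cn(-c4ccccc4)nc3-c3ccccc3)nc2c1`: 1760 nM
- compound 2, `COc1ccc2[nH]c(-c3cn(-c4ccccc4)nc3-c3ccccc3)nc2c1`: 2870 nM
- compound 3, `Clc1ccc(-c2nn(-c3ccccc3)cc2-c2nc3cc(Br)ccc3[nH]2)cc1`: 2160 nM

Of the compounds shown here, three built on a shared core have been tested in a functional assay on HeLa cells (Homo sapiens) for antiproliferative activity, read by MTT assay, with a stated time of 48 h; on this read-out higher numbers stand for weaker inhibition and lower numbers for stronger inhibition. In this assay compound 1 gives 1760 nM. Compound 2 differs from compound 1 by one change, (methoxy in place of bromo on an aromatic carbon), and in this assay compound 2 gives 2870 nM; the step is a 1.6-fold higher number from compound 1 to compound 2 (0.21 log units; within the scatter). Compound 3 differs from compound 1 by another change, (chloro in place of hydrogen on an aromatic carbon), and in this assay compound 3 gives 2160 nM, a step of a 1.2-fold higher number from compound 1 to compound 3 (0.09 log units; within the scatter). All three values lie close together.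

Compound 4, `COc1ccc2[nH]c(-c3cn(-c4ccccc4)nc3-c3ccc(Cl)cc3)nc2c1`, has not been measured in this assay. It differs from compound 3 by methoxy in place of bromo on an aromatic carbon. Among the compounds with values here, this is the same change as the one from compound 1 to compound 2: the group that leaves, the group that enters and the place described for it are the same word for word. The two cores differ as described by chloro in place of hydrogen on an aromatic carbon.

The step from compound 3 to compound 4 in this assay is expected to be about a 1.6-fold higher number from compound 3 to compound 4 (0.21 log units; within the scatter), resting on the earlier step from compound 1 to compound 2 of a 1.6-fold higher number from compound 1 to compound 2 (0.21 log units; within the scatter), since the change is the same and the cores differ only by the chloro. On that basis compound 4 is expected to give about 3500 nM in this assay, with a likely range from 1800 nM to 7000 nM.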

Compound 4, half-maximal inhibitory concentration: 3630 nM
Beside the measured number, compound 4's estimate is 1.0-fold (0.02 log units) below it, and the stated range covers the measured number.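

Methoxy in place of bromo on an aromatic carbon gives a 1.7-fold higher number from compound 3 to compound 4 (0.23 log units; within the scatter) in this assay, and set beside the same change on the core of compound 1, the step carries over with no difference that can be told apart: the same change on two cores in this assay, a 1.6-fold higher number (0.21 log units; within the scatter) from compound 1 to compound 2 and a 1.7-fold higher number (0.23 log units; within the scatter) from compound 3 to compound 4, 1.0-fold (0.01 log units) apart, within the scatter of two such steps. Read the other way round the square, chloro in place of hydrogen on an aromatic carbon gives a 1.3-fold higher number from compound 2 to compound 4 (0.10 log units; within the scatter), and this too agrees with its earlier counterpart: the same change on two cores in this assay, a 1.2-fold higher number (0.09 log units; within the scatter) from compound 1 to compound 3 and a 1.3-fold higher number (0.10 log units; within the scatter) from compound 2 to compound 4, 1.0-fold (0.01 log units) apart, within the scatter of two such steps. This shows that on these two cores neither change moves the number beyond the usual scatter, but every step here lies within that scatter, so the agreement does not show that either change has a real effect of a size that transfers, and a single pair of cores sets no rule for the series.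

The compounds shown leave open what happens when the carbon bearing bromo or methoxy carries an amine, a carboxylic acid or a longer chain such as butoxy, and whether any of these would give a step large enough to be compared across cores. They also leave open whether such a step would hold with a nitrile or a trifluoromethyl group in place of the chloro.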